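The source may hold more compounds than are shown below. What is called first, only, known or untested is meant among the compounds shown, and "the series" means these compounds.

Measured so far:

Compound 1, `Cc1ncc(S(=O)(=O)N(C)C)cc1C#Cc1cc(Cl)ccc1OCC(=O)O`, gives 41 nM in an assay on CHO cells for displacement of a labelled ligand from prostaglandin D2 receptor 2 (Homo sapiens), read by scintillation counting; on this read-out higher numbers stand for weaker inhibition and lower numbers for stronger inhibition.
Compound 2, `Cc1ccc(S(=O)(=O)CCO)cc1C#Cc1cc(Cl)ccc1OCC(=O)O`, gives 19 nM in this assay.
Compound 3, `CCCS(=O)(=O)c1ccc(C)c(C#Cc2cc(C#N)ccc2OCC(=O)O)c1`, gives 7 nM in this assay.

Compound 2 stands second highest of the three numbers. Compound 1 gives a higher number than compound 2, and compound 3 gives a lower number; both of these gaps lie beyond the usual scatter. The unmeasured compound 4, `Cc1ccc(S(=O)(=O)N2CCN(C)CC2)cc1C#Cc1cc(Cl)ccc1OCC(=O)O`, is built from compound 2 by one change: 4-methylpiperazin-1-yl in place of 2-hydroxyethyl on a sulfonyl sulfur. Within the data shown here, no measured pair shows this change, so its effect is open. The nearest clue is compound 1, where a sulfonamide gives 41 nM, a somewhat higher number than the sulfone of compound 2. The step from compound 2 to compound 4 is therefore expected to be small, toward a weaker number, near the edge of the scatter: a 2.1-fold higher number from compound 2 to compound 4 (0.32 log units; beyond the scatter). For compound 4 the estimate is 40 nM, within 15 nM to 110 nM.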

Compound 4, inhibition constant: 21 nM
Estimate against measurement, compound 4: 1.9-fold (0.28 log units) above; low and high end bracket the measured number.
By their numbers in this assay, from the lowest: compound 3; then compounds 2, 4 and 1 (each within the scatter of the next, the first and the last beyond it).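

With the rest of the molecule unchanged, the sulfonyl sulfur of compound 2 can carry 4-methylpiperazin-1-yl instead of 2-hydroxyethyl without a change beyond the scatter in this assay: the step is a 1.1-fold higher number from compound 2 to compound 4 (0.04 log units; within the scatter) and lies within it. In this one pair, a larger group with a six-membered ring and no hydrogen-bond donor reads the same as the smaller chain with one. Nothing available explains why these two groups read alike.

Still open, from the compounds shown here alone, is whether morpholin-4-yl or a piperazine lacking the methyl would read the same at this place. A longer chain ending in a carboxylic acid is also untested among the compounds shown.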